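The source may report more compounds than this note shows. Statements on the series, on what has been measured and on what is new or still open speak of the compounds shown alone.

Notes on the series. In a functional assay on A2780 cells (Homo sapiens) for inhibition, with a stated time of 72 h (on this read-out higher numbers stand for weaker inhibition and lower numbers for stronger inhibition), compound 1 `CC1(C)CCOc2ccc(NC(=O)Nc3ccc([N+](=O)[O-])cc3)cc21` gives 6700 nM. In this assay compound 2 `CC1(C)CC(C)(C)c2cc(NC(=S)Nc3ccc(C(F)(F)F)cc3)ccc2O1` gives 43700 nM. Compound 3 `CCC1(CC)CC(CC)(CC)c2cc(NC(=O)Nc3ccc(OC(F)(F)F)cc3)ccc2O1` gives 3000 nM in this assay, the lowest of the three numbers; the gap to compound 1 lies beyond the usual scatter, and the gap to compound 2 is wider still. Among the compounds with values here, compound 2 differs from the other two in more than one place, so its value is recorded as it stands and no single step is drawn from it.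

Compound 4 `CCC1(CC)CC(CC)(CC)c2cc(NC(=O)Nc3ccc(C(F)(F)F)cc3)ccc2O1` has not yet been measured in this assay. It differs from compound 3 by trifluoromethyl in place of trifluoromethoxy on an aromatic carbon. Within the data shown here, no measured pair in this set carries that change alone, so there is no step to lean on. The expected step, a 1.2-fold higher number from compound 3 to compound 4 (0.07 log units; within the scatter), lies within or close to the scatter, without a clear direction. For compound 4 the estimate in this assay is 3500 nM, with a range from 1500 nM to 9000 nM.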

Compound 4, half-maximal inhibitory concentration: 2000 nM
Estimate against measurement, compound 4: 1.8-fold (0.24 log units) above; low and high end bracket the measured number.
By their numbers in this assay, from the lowest: compounds 4 and 3 (each within the scatter of the next); then compound 1; then compound 2.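

In this assay, within the data shown here, a 1.5-fold lower number from compound 3 to compound 4 (0.18 log units; within the scatter) is the first single-place step, and it stays within the scatter. On this aromatic carbon, para to a large group, trifluoromethyl and trifluoromethoxy therefore cannot be told apart, and the oxygen of trifluoromethoxy shows no measurable contribution to the read-out. Nothing measured here bears on the reason for this result.

Going by these compounds, whether an amine or a carboxylic acid on this carbon would keep the number in the same range remains open, since both groups compared here carry three fluorines. Also open, on these data alone, is whether the same exchange would give a similarly small step on the core of compound 1.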